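The compounds below may be only part of what the source reports. "The series", "measured", "known", "first", "only" and "open" are said of these compounds alone.

In a functional assay on HT-29 cells (Homo sapiens) for cytotoxicity, read by MTT assay, with a stated time of 72 h (on this read-out lower numbers stand for higher toxicity in this test and higher numbers for lower toxicity in this test), compound 1 `CCCCC[Se]c1nc(NCc2ccc(SC)cc2)c2ccccc2n1` reaches only the limit of the test, > 100000 nM. Compound 2 `CCCCC[Se]c1nc(NCc2ccccc2)c2ccccc2n1` likewise gives only a limit, > 100000 nM. Compound 3 `C[Se]c1nc(NCc2ccccc2)c2ccccc2n1` gives only a limit as well, > 100000 nM. Among the compounds with values here, the step that the two limits leave unreadable from compound 1 to compound 2 and the step that the two limits leave unreadable from compound 2 to compound 3 cannot be sized, since every value so far sits at the limit of > 100000 nM in this assay, at which 3 of the 3 values shown sit. Compound 4 `CSc1ccc(CNc2nc(SC)nc3ccccc23)cc1` differs from compound 1 by a group of 2 heavy atoms (1 carbon, 1 sulfur; no ring) in place of a group of 6 heavy atoms (5 carbon, 1 selenium; no ring), on an aromatic carbon. Within the data shown here, no measured step covers this exchange, and none of the three measured values is a number, so neither direction nor size can be read from the series. For compound 4 the estimate in this assay is 150000 nM (30000 nM to 1000000 nM), a step that the limit leaves unreadable from compound 1 to compound 4 that is expected to leave compound 4 at the limit too.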

Compound 4, concentration lethal to 50% of the cells: > 100000 nM
Compound 4 was reported as a limit (the forecaster's own chance of this, stated with the estimate: 80%); the middle value is on the limit's open side.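

No step can be read from compound 1 to compound 4, because both values are limits: the limit of > 100000 nM in this assay, at which 4 of the 4 values shown sit.

The compounds shown leave open whether any change on the shared core gives a measurable number in this assay.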